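A Triazole in Place of Thiazole on Compound 1

A few compounds are considered here, and "the series" means these few. Any claim that something is new, unique, unknown or untested is made for them only; others in the source may bear on it.

Measured compounds:
Compound 1, `CC(C)C(Nc1nccs1)c1ccc(-c2ccc3cccc(F)c3c2)[nH]c1=O`: 10 nM
Compound 2, `CC(C)C(Cc1ncc[nH]1)c1ccc(-c2ccc3cccc(F)c3c2)[nH]c1=O`: 76 nM

In a functional assay on CHO cells for antagonist activity at prostaglandin E2 receptor EP3 subtype (Homo sapiens), read by cAMP accumulation (a lower number here means a stronger inhibitor, a higher number a weaker inhibitor), compound 1 gives 10 nM, the lowest of the two numbers shown; its nearest neighbour is compound 2, which gives 76 nM. Within the data shown here, the one measured step, a 7.6-fold higher number from compound 1 to compound 2 (0.88 log units; beyond the scatter), removed the whole (1,3-thiazol-2-yl)amino group, amine nitrogen included, and put (1H-imidazol-2-yl)methyl in its place.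

Compound 3, `CC(C)C(Nc1nnc[nH]1)c1ccc(-c2ccc3cccc(F)c3c2)[nH]c1=O`, has not yet been measured. It differs from compound 1 in one place: 4H-1,2,4-triazol-3-yl in place of 1,3-thiazol-2-yl on an amine nitrogen. Here the amine nitrogen stays and only the ring changes, so the measured step bears on this change only loosely: it shows that the region around that nitrogen is not indifferent to alteration, and that alteration there raised the number modestly. A step in the same direction but smaller is therefore expected for compound 3, though a value close to that of compound 1 cannot be excluded.

Compound 3 is estimated at 25 nM in this assay, with a range from 6 nM to 110 nM, meaning an expected step of a 2.5-fold higher number from compound 1 to compound 3 (0.40 log units; beyond the scatter).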

Compound 3, half-maximal inhibitory concentration: 185 nM
The estimate for compound 3 lay 7.4-fold (0.87 log units) below the measured number; measured number outside the range, above it.
By their numbers in this assay, from the lowest: compound 1; then compound 2; then compound 3.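

In this assay, the ring on the amine nitrogen matters in its own right: with that nitrogen kept, 4H-1,2,4-triazol-3-yl in place of 1,3-thiazol-2-yl gives a 19-fold higher number from compound 1 to compound 3 (1.27 log units; beyond the scatter), a large step between two five-membered aromatic rings of the same heavy-atom count. Keeping the amine nitrogen therefore does not preserve the low number, since the exchange of the whole group for (4H-1,2,4-triazol-3-yl)amino in place of (1H-imidazol-2-yl)methyl gives a 2.4-fold higher number from compound 2 to compound 3 (0.39 log units; beyond the scatter), so the ring exchange alone leaves the number higher than the change that removed that nitrogen did. No measurement on these compounds accounts for the size of the step, which comes with the loss of the ring sulfur and the gain of a hydrogen-bond donor.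

The compounds shown leave open which of those two differences carries the step, and whether any other ring on this amine nitrogen matches 1,3-thiazol-2-yl. A 1-methyl-1,2,4-triazolyl ring, which has no ring hydrogen on nitrogen, and a 1,3,4-thiadiazol-2-yl ring, which keeps sulfur alongside further ring nitrogen, would pull the two apart.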